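The source may report more compounds than this note shows. Statements on the series, on what has been measured and on what is new or still open speak of the compounds shown alone.

Of the compounds shown here, three sharing one core have been measured so far. Compound 1 `CCN(CC)S(=O)(=O)c1ccc(S(=O)(=O)N2CCC[C@@H](C(=O)NC3CN(C(=O)OC(C)(C)C)C3)C2)cc1` gives 200 nM in a functional assay on MIA PaCa-2 cells (Homo sapiens) for inhibition, read by MTT assay, with a stated time of 7 days; a higher number here means a weaker inhibitor, a lower number a stronger inhibitor. Compound 2 `CCN(CC)S(=O)(=O)c1ccc(S(=O)(=O)N2CCC[C@@H](C(=O)NC3CN(C(=O)C4CC4)C3)C2)cc1` gives 2800 nM in this assay, and compound 3 `CCN(CC)S(=O)(=O)c1ccc(S(=O)(=O)N2CCC[C@@H](C(=O)N(C)C(C)C)C2)cc1` gives 6200 nM, the highest of the three numbers, so compound 3 is the weakest inhibitor here. The steps show how much the group on the carbonyl carbon matters: a 31-fold higher number from compound 1 to compound 3 (1.49 log units; beyond the scatter), and a 2.2-fold higher number from compound 2 to compound 3 (0.35 log units; beyond the scatter), while a 14-fold higher number from compound 1 to compound 2 (1.15 log units; beyond the scatter) separates the two ring-bearing groups from each other.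

Compound 4 `CCN(CC)S(=O)(=O)c1ccc(S(=O)(=O)N2CCC[C@@H](C(=O)N3CCN(c4nc(C)no4)CC3)C2)cc1` is not yet measured. It differs from compound 3 in one place: 4-(3-methyl-1,2,4-oxadiazol-5-yl)piperazin-1-yl in place of isopropyl(methyl)amino on a carbonyl carbon. Both measured steps toward compound 3 point the same way: replacing isopropyl(methyl)amino with a larger, ring-bearing group gave a lower number. Compound 4 carries a group with two rings, so a lower number than compound 3 is expected, by a modest to large step, a 4.1-fold lower number from compound 3 to compound 4 (0.62 log units; beyond the scatter). The estimate for compound 4 in this assay is 1500 nM, expected to fall between 400 nM and 5000 nM.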

Compound 4, half-maximal inhibitory concentration: 250 nM
Estimate against measurement, compound 4: 6.0-fold (0.78 log units) above; the whole stated range lies above it.
By their numbers in this assay, from the lowest: compounds 1 and 4 (each within the scatter of the next); then compound 2; then compound 3.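

In this assay the 4-(3-methyl-1,2,4-oxadiazol-5-yl)piperazin-1-yl group brings a 25-fold lower number from compound 3 to compound 4 (1.39 log units; beyond the scatter) and an 11-fold lower number from compound 2 to compound 4 (1.05 log units; beyond the scatter) on this carbonyl carbon, so a ring-bearing group there does not settle the outcome on its own, since compound 2 carries rings as well. The step of a 1.3-fold higher number from compound 1 to compound 4 (0.10 log units; within the scatter) shows that a group of quite another kind, with no tert-butoxycarbonyl and no hydrogen-bond donors, can stand level with the group of compound 1. Nothing measured here explains why this change has so large an effect.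

The compounds shown leave open which part of the new group matters, the piperazine or the 3-methyl-1,2,4-oxadiazol-5-yl ring on it. A piperazine carrying an acetyl group or a phenyl ring in place of that oxadiazole would separate the two.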